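Isopropylcarbamoyl in place of the ring of compound 3

This account rests on a few compounds, and the source may have more. Where it says the series, first, only, none or still open, it means among the compounds named here.

In an ADME assay on microsomes from liver (Mus musculus) for metabolic stability (on this read-out lower numbers stand for a shorter-lived compound and higher numbers for a longer-lived compound), compound 3 `CC(C)C(Cc1noc(=O)[nH]1)c1ccc(-c2ccc3cccc(F)c3c2)[nH]c1=O` gives 2.78 h, the higher of the two actual numbers in the series. Compound 2 `CC(C)C(c1ccc(-c2ccc3cccc(F)c3c2)[nH]c1=O)N1CCN/C1=N\C#N` gives 0.207 h. Compound 1 `CC(C)C(Cc1nnc[nH]1)c1ccc(-c2ccc3cccc(F)c3c2)[nH]c1=O` reads < 0.0667 h, which is a limit of the assay and not a number.

Compound 4 `CC(C)NC(=O)CC(c1ccc(-c2ccc3cccc(F)c3c2)[nH]c1=O)C(C)C` follows from compound 3 by one change: a group of 6 heavy atoms (4 carbon, 1 nitrogen, 1 oxygen; no ring) in place of a group of 6 heavy atoms (2 carbon, 2 nitrogen, 2 oxygen; one five-membered aromatic ring with 3 hetero atoms), on a saturated chain carbon, two bonds along the chain from an aromatic carbon. Isopropylcarbamoyl, which has no ring, enters on a saturated chain carbon, two bonds along the chain from an aromatic carbon.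

Among the measured compounds shown here, two measured steps bear on this. Exchanging one ring for another at the same place gave an at least 41-fold higher number from compound 1 to compound 3 (1.61 log units; beyond the scatter), and a larger exchange of the side group gave a 13-fold higher number from compound 2 to compound 3 (1.13 log units; beyond the scatter). Both are large, and both end at compound 3. For the measured compounds named here, no measured compound lacks a ring in this group, so the estimate is loose. A lower number in this assay is expected, with an estimated step of a 5.6-fold lower number from compound 3 to compound 4 (0.75 log units; beyond the scatter). For compound 4 the expected value is 0.5 h, with an estimated range from 0.12 h to 2 h.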

Compound 4, half-life: < 0.0667 h
Compound 4: only a limit was reported; the forecaster's own chance of this, stated with the estimate: 10%; middle value at least 7.4-fold (0.87 log units) from the limit.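

In this assay compound 4 reads < 0.0667 h, which is a limit of the assay and not a number. On this saturated chain carbon, isopropylcarbamoyl, which has no ring, gives an at least 41-fold lower number from compound 3 to compound 4 (1.61 log units; beyond the scatter), and the larger exchange of the side group gives an at least 3.1-fold lower number from compound 2 to compound 4 (0.49 log units; beyond the scatter), so the longer half-life seen with the ring of compound 3 does not carry over to this open group. The step to compound 4 from compound 1, which keeps a ring, cannot be read, because both compounds stand at a limit: the limit of < 0.0667 h in this assay, at which 2 of the 4 values shown sit.

On these data alone, how far compound 4 lies under the limit stays open, so both readable steps give only a minimum size. Also open, as far as these compounds go, is whether a carboxylic acid or a primary amide at this place would hold a half-life near that of compound 3.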